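Removing an N-aryl group from a benzoxazinone core

The source may hold more compounds than are shown below. What is called first, only, known or untested is meant among the compounds shown, and "the series" means these compounds.

The study compares two cores that carry the same ring-nitrogen substituent pattern. Compound 2 `COc1ncc(-c2ccc3c(c2)N(c2ccc(F)cc2)C(=O)CO3)cc1NS(=O)(=O)c1ccc(F)cc1` and compound 1 `COc1ncc(-c2ccc3c(c2)NC(=O)CO3)cc1NS(=O)(=O)c1ccc(F)cc1` share one core; in a functional assay on A549 cells (Homo sapiens) for antiproliferative activity, read by MTT assay, with a stated time of 72 h (on this read-out lower numbers stand for stronger inhibition and higher numbers for weaker inhibition), compound 2 gives 6500 nM and compound 1 gives 8070 nM. The change between them is hydrogen in place of 4-fluorophenyl on an amide-type nitrogen in a ring, and it made a 1.2-fold higher number from compound 2 to compound 1 (0.09 log units; within the scatter). Compound 3 `O=C1COc2ccc(-c3cnc4ccccc4c3)cc2N1c1ccc(F)cc1` is built on a second core, and how it differs from compound 2 is not broken down here. In this assay compound 3 reaches only a limit of the assay, > 40000 nM, so that it sits at the limit of > 40000 nM in this assay, at which 1 of the 3 values shown sits. Compound 4 `O=C1COc2ccc(-c3cnc4ccccc4c3)cc2N1` has not yet been measured in this assay; it differs from compound 3 by hydrogen in place of 4-fluorophenyl on an amide-type nitrogen in a ring, the same change that was made from compound 2 to compound 1. Since that earlier step stayed within the scatter, the expectation for compound 4 is a step that the limit leaves unreadable from compound 3 to compound 4 from compound 3, resting on the small size of a 1.2-fold higher number from compound 2 to compound 1 (0.09 log units; within the scatter). Compound 4 is therefore estimated at 45000 nM in this assay, with a range from 20000 nM to 100000 nM, and a real chance that the assay again reports only a limit.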

Compound 4, half-maximal inhibitory concentration: > 40000 nM
Compound 4 gave a limit, no number (the forecaster's own chance of this, stated with the estimate: 65%); the middle value lies beyond the limit too.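

In this assay, going by these compounds alone, compound 3 and compound 4 each return only a limit of the assay, not a number, so no step between them can be read: the limit of > 40000 nM in this assay, at which 2 of the 4 values shown sit. The compounds shown leave open whether hydrogen in place of 4-fluorophenyl on the core of compound 3 alters antiproliferative activity at all.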